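This account rests on a few compounds, and the source may have more. Where it says the series, first, only, none or still open, it means among the compounds named here.

In an in vivo functional assay on the whole organism for inhibition, with Rattus norvegicus as the target (a lower number here means that less compound is needed, a higher number that more compound is needed for the effect), the shared core carries different side groups, and so far the data are thin. Compound 1 (`CCCc1nc(C)c(CC(=O)N(CC)CC)c(=O)n1Cc1ccc(-c2ccccc2-c2nnn[nH]2)cc1`) has no usable result: compound 1 stands as "not determined" (no result reported) in this record. For the measured compounds named here, compound 2 (`CCCCc1nc(C)c(CC(=O)N2CCC[C@H]2C(=O)OC)c(=O)n1Cc1ccc(-c2ccccc2-c2nnn[nH]2)cc1`) gives 0.043 mg/kg as its half-maximal dose, and it is the only number available, so it cannot yet be ranked against anything.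

Compound 3 (`CCCCc1nc(C)c(CCC(=O)N2CCSCC2)c(=O)n1Cc1ccc(-c2ccccc2-c2nnn[nH]2)cc1`) has not been measured. It differs from compound 2 by one change (((thiomorpholin-4-yl)carbonyl)methyl in place of (2-(methoxycarbonyl)pyrrolidin-1-yl)carbonyl on a saturated chain carbon bound to an aromatic carbon): ((thiomorpholin-4-yl)carbonyl)methyl stands in place of (2-(methoxycarbonyl)pyrrolidin-1-yl)carbonyl on a saturated chain carbon bound to an aromatic carbon. The defined stereocentre of compound 2 leaves with the old group.

Going by the values given here, no measured pair shows what a change like this does, so any forecast is loose. A moderate shift towards needing more compound seems the likelier outcome, and the estimated step is a 2.8-fold higher number from compound 2 to compound 3 (0.45 log units; beyond the scatter) in size, though a result within the usual scatter would be no surprise. For compound 3 the expected dose in this assay is about 0.12 mg/kg with an estimated range from 0.03 mg/kg to 0.5 mg/kg for the coming measurement.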

Compound 3, dose for half-maximal effect: 0.204 mg/kg
Estimate against measurement, compound 3: 1.7-fold (0.23 log units) below; low and high end bracket the measured number.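

For the compounds shown here, the first measured step at this place, on a saturated chain carbon bound to an aromatic carbon, is a 4.7-fold higher number from compound 2 to compound 3 (0.68 log units; beyond the scatter) in this assay, so the dose needed does respond to the group carried here. This is one bundled change, not a single edit: the five-membered ring with its methoxycarbonyl group and defined stereocentre gives way to a six-membered ring with two hetero atoms, and read one bond further out, ((2-(methoxycarbonyl)pyrrolidin-1-yl)carbonyl)methyl becomes 2-((thiomorpholin-4-yl)carbonyl)ethyl, so the chain to the carbonyl differs too. No measured information explains the step.

The compounds shown leave open which of these differences accounts for the step, as no pair separates the ring, the ester, the stereocentre or the chain. Also open, from the compounds shown here alone, is how this assay would respond to a morpholine ring in place of the thiomorpholine, or to a free carboxylic acid in place of the methyl ester on the pyrrolidine ring.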